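The source may hold more compounds than are shown below. What is called first, only, known or untested is meant among the compounds shown, and "the series" means these compounds.

Measured compounds in an ADME assay on RAW264.7 cells (Mus musculus) for cytotoxicity, read by MTT assay, with a stated time of 24 h; on this read-out higher numbers stand for lower toxicity in this test and lower numbers for higher toxicity in this test:
compound 1 `O=C(Nc1ccc(Br)cc1F)c1cc(F)ccc1O`: compound 1 gives 7900 nM
compound 2 `O=C(Nc1ccc(Cl)cc1F)c1cc(F)ccc1O`: compound 2 gives 7700 nM
compound 3 `O=C(Nc1ccc(Br)cc1F)c1cc(Br)ccc1O`: compound 3 gives 7800 nM

All three values lie within the scatter of one another in this assay. Compound 4 `O=C(Nc1ccc(Br)cc1F)c1cc(Cl)ccc1O` is not yet measured. It differs from compound 3 by chloro in place of bromo on an aromatic carbon. The same kind of change was made from compound 1 to compound 2, (chloro in place of bromo on an aromatic carbon), and gave a 1.0-fold lower number from compound 1 to compound 2 (0.01 log units; within the scatter). The places are not the same word for word: in compound 1 the carbon is meta to a fluoro group and para to a large group, in compound 3 it is meta to a large group and para to a hydroxy group, so this is the same kind of change, not the same. The two cores differ by bromo in place of fluoro on an aromatic carbon, with a 1.0-fold lower number from compound 1 to compound 3 (0.01 log units; within the scatter). A step of no change at the digits printed from compound 3 to compound 4 (within the scatter) is expected because the earlier step of a 1.0-fold lower number from compound 1 to compound 2 (0.01 log units; within the scatter) stayed within the scatter. Compound 4 is estimated at 7800 nM, between 4000 nM and 15000 nM.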

Compound 4, half-maximal cytotoxic concentration: 7800 nM
Compound 4: the middle estimate sits on the measured number at the digits printed; the measured number falls inside the stated range.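

In this assay, chloro in place of bromo on an aromatic carbon reads alike on the two cores: the same change on two cores in this assay, a 1.0-fold lower number (0.01 log units; within the scatter) from compound 1 to compound 2 and no change at the digits printed (within the scatter) from compound 3 to compound 4, 1.0-fold (0.01 log units) apart, within the scatter of two such steps. The new step is no change at the digits printed from compound 3 to compound 4 (within the scatter), and chloro in place of fluoro gives a 1.0-fold lower number from compound 1 to compound 4 (0.01 log units; within the scatter), so no step shown here lies beyond the scatter. This shows that the exchange is silent on both cores, but it does not show that a change with a real effect would carry over, and two cores make no general rule.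

All the compounds shown vary only among halogens, so it remains open whether any other kind of group would shift this read-out. An amine, a carboxylic acid or a methoxy group para to the hydroxy group would test this.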